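Cytotoxicity limits across a methoxy-to-nitro pair

The source may report more compounds than this note shows. Statements on the series, on what has been measured and on what is new or still open speak of the compounds shown alone.

Compound 1 `CCc1c(Cc2cc(C)cc(C)c2)nc(SCc2ccc(OC)cc2)[nH]c1=O` and compound 2 `CCc1c(Cc2cc(C)cc(C)c2)nc(SCc2ccc([N+](=O)[O-])cc2)[nH]c1=O` share one core; compound 3 `CCc1c(Cc2cc(C(F)(F)F)cc(C(F)(F)F)c2)nc(SCc2ccc(OC)cc2)[nH]c1=O` and compound 4 `CCc1c(Cc2cc(C(F)(F)F)cc(C(F)(F)F)c2)nc(SCc2ccc([N+](=O)[O-])cc2)[nH]c1=O` share another, and the difference between the two cores is not broken down here. In an ADME assay on MT4 cells (Homo sapiens) for cytotoxicity, read by MTT assay (a higher number here means that more compound is tolerated, a lower number that less compound is tolerated), compound 1 is reported only as the limit > 317000 nM. Compound 2 likewise sits at the limit > 305000 nM in this assay. Compound 3 is also reported as a limit, > 249000 nM, in this assay. The change nitro in place of methoxy on an aromatic carbon gives a step that the two limits leave unreadable from compound 1 to compound 2. The same change, (nitro in place of methoxy on an aromatic carbon), carries compound 3 to compound 4, with the place described in identical words for both pairs. Because compound 3 gives > 249000 nM, compound 4 is expected to stay at a limit too, the step being a step that the limit leaves unreadable from compound 3 to compound 4. Compound 4 is expected at 300000 nM in this assay, most likely reported again only as a limit.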

Compound 4, half-maximal cytotoxic concentration: > 242000 nM
Compound 4: no number, only a limit; the forecaster's own chance of this, stated with the estimate: 85%; the middle value lies beyond the limit too.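

Compound 3 and compound 4 both stand only as limits in this assay, and the step between them cannot be read. The compounds shown leave open at what concentration any of them becomes cytotoxic.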